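The compounds below may be only part of what the source reports. "The series", "measured", "known", "first", "only" and "open" are said of these compounds alone.

Working notes on the series. The common core is the amide bearing the pentafluorophenyl-sulfonylated four-membered ring, with a substituted pyridylmethyl or benzyl group and an aryl group on the amide nitrogen. In a functional assay on MCF7 cells (Homo sapiens) for antiproliferative activity, with a stated time of 72 h (on this read-out higher numbers stand for an effect only at larger amounts of compound and lower numbers for an effect already at smaller amounts), compound 1 `COC(=O)c1ccc(N(Cc2cnc(C3CCCCC3)cn2)C(=O)[C@H]2CCN2S(=O)(=O)c2c(F)c(F)c(F)c(F)c2F)cc1O` gives 5700 nM. In this assay compound 2 `O=C1OCc2cc(N(Cc3ccc(C4CCCCC4)cn3)C(=O)[C@H]3CCN3S(=O)(=O)c3c(F)c(F)c(F)c(F)c3F)ccc21` gives 4600 nM. In this assay compound 3 `O=C(NO)c1cc(F)c(N(Cc2ccc(C3CCOCC3)cc2)C(=O)[C@H]2CCN2S(=O)(=O)c2c(F)c(F)c(F)c(F)c2F)cc1O` is recorded as "not determined" (no result reported), so no result is available for it. For the measured compounds named here, of the two numbers recorded, the one for compound 2 is the lowest, but compound 1 sits within the scatter of it, so the two are not distinguished. Compound 4 `O=C([C@H]1CCN1S(=O)(=O)c1c(F)c(F)c(F)c(F)c1F)N(Cc1ccc(C2CCCCC2)cn1)c1ccc2c(=O)[nH]ccc2c1` remains to be measured in this assay. It differs from compound 2 in one place: a group of 11 heavy atoms (9 carbon, 1 nitrogen, 1 oxygen; one six-membered aromatic ring of carbon only, one six-membered aromatic ring with 1 hetero atom) in place of a group of 10 heavy atoms (8 carbon, 2 oxygen; one five-membered non-aromatic ring with 1 hetero atom, one six-membered aromatic ring of carbon only), on an amide-type nitrogen. Both groups are bicyclic and carry a carbonyl, so the change is of modest size. Going by the values given here, with only two numbers recorded and no single-point step between measured compounds, there is no basis to expect a move in this assay beyond the scatter in either direction. The estimate for compound 4 in this assay is 4000 nM, with a range from 1500 nM to 12000 nM. The expected step from compound 2 to compound 4 in this assay is a 1.2-fold lower number from compound 2 to compound 4 (0.06 log units; within the scatter), held near zero for lack of any guiding step.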

Compound 4, half-maximal effective concentration: 2200 nM
The estimate for compound 4 lay 1.8-fold (0.26 log units) above the measured number, and the stated range covers the measured number.
By their numbers in this assay, from the lowest: compound 4; then compounds 2 and 1 (each within the scatter of the next).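

The exchange on the amide-type nitrogen, whose other neighbours are the carbonyl carbon and a saturated chain carbon, is the only single-place step among the compounds shown, and in this assay it gives a 2.1-fold lower number from compound 2 to compound 4 (0.32 log units; beyond the scatter), modest in size but beyond the scatter. This position therefore responds to the choice of bicyclic group: the group with one six-membered aromatic ring of carbon only and one six-membered aromatic ring with 1 hetero atom, carrying 1 hydrogen-bond donor and 1 hydrogen-bond acceptor, gives the lower number, compared with the group containing one five-membered non-aromatic ring, with 0 hydrogen-bond donors and 2 hydrogen-bond acceptors. No measurement at hand explains the step, so these counts only describe the change.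

A single step cannot separate the contribution of the ring exchange from that of the different donor and acceptor counts. Going by these compounds, it also remains open how the number would respond at this place to a bicyclic group bearing an amine or a carboxylic acid, and whether the same exchange would give a similar step with other groups elsewhere on the shared core.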